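Triazole series: dichlorophenyl variant of compound 1

A few compounds are considered here, and "the series" means these few. Any claim that something is new, unique, unknown or untested is made for them only; others in the source may bear on it.

Compound 1, `COc1cc(-c2ncnn2-c2ccccc2)cc(OC)c1OC`, is measured in a functional assay on Jurkat cells (Homo sapiens) for antiproliferative activity, read by MTT assay, with a stated time of 72 h; on this read-out higher numbers stand for weaker inhibition and lower numbers for stronger inhibition. In this assay compound 1 gives > 10000 nM, which is a limit of the assay and not a number. Compound 2, `COc1cc(-n2ncnc2-c2ccc(F)cc2)cc(OC)c1OC`, also returns only a limit in this assay, > 10000 nM. Compound 3, `COc1cc(-n2ncnc2-c2ccc(C)cc2)cc(OC)c1OC`, gives 300 nM in this assay. Among the measured compounds shown here, the only step between measured compounds that differ in one place is an at least 33-fold lower number from compound 2 to compound 3 (1.52 log units; beyond the scatter), which shows that a single substituent change on an aryl ring can move the read-out well beyond the scatter; the two compounds that remain without a number share (the limit of > 10000 nM in this assay, at which 2 of the 3 values shown sit).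

Compound 4, `COc1cc(-c2ncnn2-c2ccc(Cl)c(Cl)c2)cc(OC)c1OC`, is not yet measured. It differs from compound 1 as follows: 3,4-dichlorophenyl in place of phenyl on an aromatic nitrogen. For the measured compounds named here, no measured step concerns this change or this ring; the step from compound 2 to compound 3 concerns another aryl ring and another pair of substituents, so it offers only the general size that such a change can reach. As far as these compounds go, because compound 1 stands at > 10000 nM, the starting point itself is unknown, and a large share of chance remains that compound 4 also returns only a limit. The estimate for compound 4 in this assay is 4000 nM, with a range from 800 nM to 20000 nM. This estimate would mean an at least 2.5-fold lower number from compound 1 to compound 4 (0.39 log units; beyond the scatter), expected but weakly grounded.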

Compound 4, half-maximal inhibitory concentration: > 10000 nM
Compound 4: no number, only a limit; the forecaster's own chance of this, stated with the estimate: 50%; middle value at least 2.5-fold (0.39 log units) from the limit.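

Compound 4, like compound 1, returns only a limit of the assay and not a number, so no step can be read between the two compounds: the limit of > 10000 nM in this assay, at which 3 of the 4 values shown sit.

What the compounds shown leave open is whether 3,4-dichlorophenyl in place of phenyl on the aromatic nitrogen changes the read-out at all, and in which direction.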